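Pyridinyl-oxadiazole acylhydrazones: a cinnamylidene variant

The source may report more compounds than this note shows. Statements on the series, on what has been measured and on what is new or still open speak of the compounds shown alone.

Measured compounds:
compound 1 `COc1ccc(/C=N/NC(=O)CSc2nnc(-c3ccncc3)o2)cc1` — 20300 nM
compound 2 `O=C(CSc1nnc(-c2ccncc2)o1)N/N=C/c1cc(Cl)cc(Cl)c1O` — 5030 nM

Two compounds share the core and differ only in the group on the carbon with a double bond to nitrogen. In a functional assay on SW 1116 cells (Homo sapiens) for cytotoxicity, read by MTT assay, with a stated time of 48 h (on this read-out higher numbers stand for weaker inhibition and lower numbers for stronger inhibition), compound 1 gives 20300 nM, the highest of the two numbers; its nearest neighbour is compound 2 with 5030 nM, reached by a 4.0-fold lower number from compound 1 to compound 2 (0.61 log units; beyond the scatter).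

Compound 3 `O=C(CSc1nnc(-c2ccncc2)o1)N/N=C/C=C/c1ccccc1` is not yet measured. It differs from compound 1 as follows: 2-phenylethenyl in place of 4-methoxyphenyl on a carbon with a double bond to nitrogen.

Among the measured compounds shown here, only the step from compound 1 to compound 2 is available, and it concerns a different replacement at the same place, so it bears on compound 3 only loosely. For the measured compounds named here, the one measured step shows that the group on this carbon can move the number beyond the scatter, but gives no direction for a 2-phenylethenyl group. For compound 3 a step of a 1.4-fold lower number from compound 1 to compound 3 (0.13 log units; within the scatter) is therefore expected, within the scatter. Compound 3 is estimated at 15000 nM, with a range from 5000 nM to 45000 nM.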

Compound 3, half-maximal inhibitory concentration: 14900 nM
Beside the measured number, compound 3's estimate is 1.0-fold (0.00 log units) above it; measured number inside the range.
By their numbers in this assay, from the lowest: compound 2; then compounds 3 and 1 (each within the scatter of the next).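

In this assay, the change on the carbon with a double bond to nitrogen gives a 1.4-fold lower number from compound 1 to compound 3 (0.13 log units; within the scatter), so an all-carbon 2-phenylethenyl group, with its double bond outside aromatic rings, reads no differently from 4-methoxyphenyl at this position. Among the compounds shown here, measured against the other end of the series, the same group gives a 3.0-fold higher number from compound 2 to compound 3 (0.47 log units; beyond the scatter), which leaves 3,5-dichloro-2-hydroxyphenyl as the only one of the three groups that stands apart, with the lowest number. Nothing among the data offers a cause for either step.

The compounds shown leave open whether the lower number of compound 2 goes with its chlorines or with its hydroxy group, as these occur only together here. They also leave open how a saturated 2-phenylethyl chain, or a 2-phenylethenyl group carrying chlorine or a dimethylamino group on its ring, would read at this position.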